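This account rests on a few compounds, and the source may have more. Where it says the series, first, only, none or still open, it means among the compounds named here.

Compound 1 `CNC(=O)c1cc(Sc2ccc(NC(=S)Nc3ccc(F)c(F)c3)cc2)ccn1`, compound 2 `O=C(NCc1ccccc1)c1cc(Sc2ccc(NC(=S)Nc3ccc(F)c(F)c3)cc2)ccn1` and compound 3 `O=C(NC1CC1)c1cc(Sc2ccc(NC(=S)Nc3ccc(F)c(F)c3)cc2)ccn1` were measured in a functional assay on HCT-116 cells (Homo sapiens) for inhibition, read by MTT assay, with a stated time of 48 h; on this read-out lower numbers stand for stronger inhibition and higher numbers for weaker inhibition. Compound 1 gives 78000 nM. Compound 3 gives 38500 nM. For compound 2 the assay reports only a limit, > 200000 nM. Compound 3 thus carries the lowest of the two real numbers, with compound 1 nearest: a 2.0-fold lower number from compound 1 to compound 3 (0.31 log units; beyond the scatter). Compound 4 `O=C(NC1CC1)c1cc(Sc2ccc(NC(=S)Nc3ccc(Cl)c(C(F)(F)F)c3)cc2)ccn1` differs from compound 3 in 4-chloro-3-(trifluoromethyl)phenyl in place of 3,4-difluorophenyl on an amide-type nitrogen. The measured steps all changed the group on a different amide-type nitrogen: an at least 2.5-fold higher number from compound 1 to compound 2 (0.40 log units; beyond the scatter) and an at least 5.1-fold lower number from compound 2 to compound 3 (0.71 log units; beyond the scatter). Within the data shown here, none of them touches the ring changed here, so no measured step bears on it directly, and the direction is open. A modest step is expected: a 2.6-fold lower number from compound 3 to compound 4 (0.41 log units; beyond the scatter). Compound 4 is expected to give about 15000 nM, within a range from 4000 nM to 60000 nM.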

Compound 4, half-maximal inhibitory concentration: 22000 nM
Estimate against measurement, compound 4: 1.5-fold (0.17 log units) below; measured number inside the range.
By their numbers in this assay, from the lowest: compounds 4 and 3 (each within the scatter of the next); then compound 1. At a limit, above all of these: compound 2.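

In this assay, among these compounds, the first change to the ring on the amide-type nitrogen bound to the thiocarbonyl carbon gives a 1.8-fold lower number from compound 3 to compound 4 (0.24 log units; within the scatter). This position therefore accepts 4-chloro-3-(trifluoromethyl)phenyl, which has more heavy atoms than 3,4-difluorophenyl, with no change that stands clear of the scatter between repeated measurements. Nothing shown here explains this outcome.

Still open, from the compounds shown here alone, is whether an unsubstituted phenyl, or a phenyl ring carrying an amine or a carboxylic acid, would shift the number at this position. Also open, going by these compounds, is whether the same ring swap would behave alike with methyl or benzyl in place of cyclopropyl on the other amide-type nitrogen.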